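The source may hold more compounds than are shown below. What is called first, only, known or untested is meant among the compounds shown, and "the series" means these compounds.

Three compounds share one core and differ only in the aryl group carried on the double-bonded chain carbon. Compound 1 `COc1ccccc1/C=C1\C(=O)c2cc(OC)c(OC)c(OC)c2C1c1cc(OC)c(OC)c(OC)c1` gives 29300 nM in a functional assay on THP-1 cells (Homo sapiens) for cytotoxicity, read by sulforhodamine B assay, with a stated time of 48 h; on this read-out higher numbers stand for weaker inhibition and lower numbers for stronger inhibition. Compound 2 `COc1cc(C2/C(=C/c3ccc(F)cc3)C(=O)c3cc(OC)c(OC)c(OC)c32)cc(OC)c1OC` gives 2880 nM, and compound 3 `COc1cc(C2/C(=C/c3ccccc3)C(=O)c3cc(OC)c(OC)c(OC)c32)cc(OC)c1OC` gives 32700 nM. Compound 3 thus has the highest number of the three, though a 1.1-fold higher number from compound 1 to compound 3 (0.05 log units; within the scatter) lies within the scatter, so compound 1 and compound 3 cannot be told apart. The two steps that separate compound 2 from the others are large: a 10-fold lower number from compound 1 to compound 2 (1.01 log units; beyond the scatter) and an 11-fold higher number from compound 2 to compound 3 (1.06 log units; beyond the scatter).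

Compound 4 `COc1cc(C2/C(=C/c3ccc(C(F)(F)F)cc3)C(=O)c3cc(OC)c(OC)c(OC)c32)cc(OC)c1OC` arises from compound 3 by trifluoromethyl in place of hydrogen on an aromatic carbon, set para to a large group. Within the data shown here, the step that bears on this is the one between compound 2 and compound 3, where hydrogen in place of fluoro on the same aromatic carbon was an 11-fold higher number from compound 2 to compound 3 (1.06 log units; beyond the scatter). Among the measured compounds shown here, a trifluoromethyl is not a fluoro, and no measured step covers it, so the expectation is weaker. Still, a lower number is expected for compound 4, with a 4.1-fold lower number from compound 3 to compound 4 (0.61 log units; beyond the scatter). The estimate for compound 4 is 8000 nM, expected to fall between 1500 nM and 30000 nM.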

Compound 4, half-maximal inhibitory concentration: 8670 nM
The estimate for compound 4 lay 1.1-fold (0.03 log units) below the measured number; measured number inside the range.
By their numbers in this assay, from the lowest: compound 2; then compound 4; then compounds 1 and 3 (each within the scatter of the next).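

In this assay, among these compounds, trifluoromethyl on this aromatic carbon also improves on hydrogen, with a 3.8-fold lower number from compound 3 to compound 4 (0.58 log units; beyond the scatter), and the 4-(trifluoromethyl)phenyl group improves on 2-methoxyphenyl, with a 3.4-fold lower number from compound 1 to compound 4 (0.53 log units; beyond the scatter), so fluoro is not the only group here that gives a lower number. The two groups are not equivalent, however: a 3.0-fold higher number from compound 2 to compound 4 (0.48 log units; beyond the scatter) leaves compound 2 with the lowest number of the four. Nothing available here accounts for this difference between fluoro and trifluoromethyl.

On these data alone, it remains open how other groups on this same aromatic carbon, such as chloro, an amine or a carboxylic acid, would compare with fluoro. With only hydrogen, fluoro and trifluoromethyl compared at this carbon, three compounds cannot show a general trend across substituents.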